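A few compounds are considered here, and "the series" means these few. Any claim that something is new, unique, unknown or untested is made for them only; others in the source may bear on it.

In a functional assay on HeLa cells (Homo sapiens) for inhibition, with a stated time of 72 h (a lower number here means a stronger inhibitor, a higher number a weaker inhibitor), compound 1 `COC(=O)C[C@H](NC(=O)OC(C)(C)C)C(=O)N(Cc1ccccc1)C1(C(=O)NC2CCCCC2)CCN(Cc2ccccc2)CC1` gives 21000 nM and compound 2 `COC(=O)C[C@H](NC(=O)OC(C)(C)C)C(=O)N(Cc1ccc(F)cc1)C1(C(=O)NCc2ccccc2)CCN(Cc2ccccc2)CC1` gives 19000 nM. Within the data shown here, compound 2 therefore stands within the usual scatter of the only other measured compound. Compound 3 `COC(=O)C[C@H](NC(=O)OC(C)(C)C)C(=O)N(C1CC1)C1(C(=O)NCc2ccccc2)CCN(Cc2ccccc2)CC1` has cyclopropyl in place of 4-fluorobenzyl on an amide-type nitrogen. Among the measured compounds shown here, no measured pair tests this change, so any expectation remains loose. A modest step toward weaker inhibition in this assay is expected: a 1.6-fold higher number from compound 2 to compound 3 (0.20 log units; within the scatter). The estimated value for compound 3 is 30000 nM, with an expected range from 12000 nM to 80000 nM.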

Compound 3, half-maximal inhibitory concentration: 7900 nM
Beside the measured number, compound 3's estimate is 3.8-fold (0.58 log units) above it, outside the stated range (below it).
By their numbers in this assay, from the lowest: compound 3; then compounds 2 and 1 (each within the scatter of the next).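

Swapping 4-fluorobenzyl for cyclopropyl on the amide-type nitrogen, with 3 heavy atoms entering and 8 leaving, gives in this assay a 2.4-fold lower number from compound 2 to compound 3 (0.38 log units; beyond the scatter). This shows that the group at this position affects the read-out, and that an aromatic ring is not needed there for inhibition at this level. Nothing measured here explains the step. Among these compounds, with only this one pair, it remains open how methyl, an unbranched propyl chain or a chain ending in an amine would behave on this nitrogen. Whether the step holds with other groups elsewhere on the shared core is also unknown.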